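A phosphate in place of a methyl on the shared core

The source may report more compounds than this note shows. Statements on the series, on what has been measured and on what is new or still open speak of the compounds shown alone.

Of the compounds shown here, two with the same core have been measured in a functional assay on HL-60 cells (Homo sapiens) for inhibition, read by MTT assay, with a stated time of 72 h; a higher number here means a weaker inhibitor, a lower number a stronger inhibitor. Compound 1 `Cc1nc(-c2cccc(O)c2)c(C(=O)N2CCN(c3cccc(Cl)c3)CC2)o1` carries a free hydroxyl on its pendant aromatic ring, and in this assay compound 1 gives 105 nM. Compound 2 `COc1cccc(-c2nc(C)oc2C(=O)N2CCN(c3cccc(Cl)c3)CC2)c1` carries a methoxy group in the same position; in this assay compound 2 is reported as "not active" (no number reported), so no number places it among the others, and the comparison with compound 1 rests only on the two reported outcomes.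

Compound 3 `Cc1nc(-c2cccc(OP(=O)(O)O)c2)c(C(=O)N2CCN(c3cccc(Cl)c3)CC2)o1` has not yet been measured in this assay. It differs from compound 2 by a single change: a group of 4 heavy atoms (3 oxygen, 1 phosphorus; no ring) in place of one carbon atom, on an oxygen on an aromatic ring. Going by the values given here, no measured pair follows this exact step, so the size of the expected change cannot be read from a neighbouring comparison. Since compound 2 has no number, the direction of the step can only be set against compound 1, whose value of 105 nM marks the potency of the free phenol. Compound 3 is expected to fall near but somewhat above that, estimated at 300 nM with a range of 60 nM to 3000 nM.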

Compound 3, half-maximal inhibitory concentration: > 1000 nM
Compound 3: a limit, no number (the forecaster's own chance of this, stated with the estimate: 25%); at least 3.3-fold (0.52 log units) between middle value and limit.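

In this assay compound 3 gives a limit and not a number: the limit of > 1000 nM in this assay, at which 1 of the 3 values shown sits.

Putting the phosphate on the oxygen of the free hydroxyl, in place of its hydrogen, gives an at least 9.5-fold higher number from compound 1 to compound 3 (0.97 log units; beyond the scatter) in this assay, so at this oxygen on the aromatic ring the change costs potency by a margin that the limit only bounds. Until now the free hydroxyl had been set only against the methoxy group of compound 2; this result shows that a second, much larger group on the same oxygen also fails to match it, and among these three compounds only compound 1 has a number, 105 nM. The step from compound 2 to compound 3 cannot be read, since neither compound has a number.

Going by these compounds, how far compound 3 lies past its limit stays open, and so does any ordering of the methoxy and phosphate groups. Also open, on these data alone, is whether a smaller group on this oxygen, such as an acetyl, or an amine in place of the hydroxyl, would keep the potency of compound 1 in this assay.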